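A second chloro on the aryl ring of compound 2

This account rests on a few compounds, and the source may have more. Where it says the series, first, only, none or still open, it means among the compounds named here.

Of the compounds shown here, three sharing one core have so far been tested in a functional assay on HEp-2 cells (Homo sapiens) for cytotoxicity, read by MTT assay, with a stated time of 72 h, tested at 1.25 ug/mL; on this read-out lower numbers stand for less inhibition of growth and higher numbers for more inhibition of growth at the one concentration tested. Compound 1 `O=C1NC(=S)/C(=C/c2ccccc2Br)S1` gives 3.14%. Compound 2 `O=C1NC(=S)/C(=C/c2ccccc2Cl)S1` gives -11.3%, and compound 3 `O=C1NC(=S)/C(=C/c2ccc(Cl)cc2Cl)S1` gives 6.83%. Among these three numbers compound 2 stands lowest: compound 1 is the nearest to it and compound 3 the furthest, both reading higher, and both gaps are beyond the scatter. The step of a number 14.4 percentage points lower from compound 1 to compound 2 (beyond the scatter) came with chloro in place of bromo on an aromatic carbon, and the step of a number 18.1 percentage points higher from compound 2 to compound 3 (beyond the scatter) came with chloro in place of hydrogen on an aromatic carbon.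

Compound 4 `O=C1NC(=S)/C(=C/c2c(Cl)cccc2Cl)S1` has not yet been measured in this assay. It differs from compound 2 by chloro in place of hydrogen on an aromatic carbon. The measured step that bears on this change is the one in which a chloro likewise entered in place of a hydrogen and the reading rose by a modest amount, though there the chloro sat on a different carbon of the ring, so that step is a guide rather than a match. A modest rise is therefore expected, of about a number 11.3 percentage points higher from compound 2 to compound 4 (beyond the scatter). Compound 4 is estimated to give 0%, with a range from -15% to 15%.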

Compound 4, percent growth inhibition at one concentration: -9.16%
For compound 4 the middle estimate is 9.2 percentage points above the measured one; measured number inside the range.
By their numbers in this assay, from the lowest: compounds 2 and 4 (each within the scatter of the next); then compounds 1 and 3 (each within the scatter of the next).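

In this assay a chloro added to compound 2 on this carbon, ortho to a group of 8 heavy atoms and meta to a chloro group, gives a number 2.1 percentage points higher from compound 2 to compound 4 (within the scatter) and so no change that can be told apart from ordinary repeat-to-repeat variation. The same swap of a hydrogen for a chloro on a different carbon of the ring gave a number 18.1 percentage points higher from compound 2 to compound 3 (beyond the scatter) so, in these two steps from compound 2, the outcome of adding a chloro differs with the ring carbon that receives it. No measurement at hand explains why these two carbons behave differently.

As far as these compounds go, whether this flat result is particular to chloro stays open, since a fluoro, a methyl group or an amine on the same carbon could read differently. From the compounds shown here alone, all of these numbers also come from a single concentration in one cell type, so how the compounds would compare across a range of concentrations remains unknown.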